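Trading a Cyclic Carbamate for a Small Hydroxyalkyl Chain

This account rests on a few compounds, and the source may have more. Where it says the series, first, only, none or still open, it means among the compounds named here.

Compound 1 `CC(C)c1n[nH]c2c(NCc3ccc(-c4ccccn4)cc3)nc(SCC(O)CO)nc12`: 21 nM
Compound 2 `CC(C)c1n[nH]c2c(NCc3ccc(-c4ccccn4)cc3)nc(SCC3CNC(=O)O3)nc12`: 80 nM
Compound 3 `CC(C)c1n[nH]c2c(NCc3ccc(-c4ccccn4)cc3)nc(SCC(O)C(F)(F)F)nc12`: 690 nM

In a functional assay on HT cells (Homo sapiens) for antiproliferative activity, read by fluorescence, with a stated time of 72 h (a higher number here means a weaker inhibitor of growth, a lower number a stronger inhibitor of growth), compound 2 holds the second highest number of the three, sitting a 3.8-fold higher number from compound 1 to compound 2 (0.58 log units; beyond the scatter) and an 8.6-fold higher number from compound 2 to compound 3 (0.94 log units; beyond the scatter). Compound 4 `CC(C)c1n[nH]c2c(NCc3ccc(-c4ccccn4)cc3)nc(SC(C)C(C)O)nc12` differs from compound 2 in one place: 2-hydroxy-1-methylpropyl in place of (2-oxo-1,3-oxazolidin-5-yl)methyl on a sulfur. Within the data shown here, no measured step covers this exact exchange; the closest guide is that the dihydroxyethyl chain of compound 1 gave the lowest number, while the trifluoro chain of compound 3 gave the highest, so small hydroxyalkyl chains in this position are tolerated well. A modest downward step is therefore expected, a 2.0-fold lower number from compound 2 to compound 4 (0.30 log units; within the scatter), with little chance of a limit. Compound 4 is estimated at 40 nM, within a range from 12 nM to 140 nM.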

Compound 4, concentration for 50% growth inhibition: 190 nM
Compound 4: the middle estimate sits 4.8-fold (0.68 log units) below what was measured; measured number above the stated range.
By their numbers in this assay, from the lowest: compound 1; then compound 2; then compound 4; then compound 3.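

On the sulfur, replacing the ring with an open chain does not lower the number (a 2.4-fold higher number from compound 2 to compound 4 (0.38 log units; beyond the scatter)), so a small hydroxyalkyl chain is not automatically better than the (2-oxo-1,3-oxazolidin-5-yl)methyl group. The 2-hydroxy-1-methylpropyl chain improves on the 3,3,3-trifluoro-2-hydroxypropyl chain (a 3.6-fold lower number from compound 3 to compound 4 (0.56 log units; beyond the scatter)) but falls well short of the 2,3-dihydroxypropyl chain (a 9.0-fold higher number from compound 1 to compound 4 (0.96 log units; beyond the scatter)), so a hydroxyalkyl chain alone does not reach the number of compound 1. No available evidence bears on why these chains differ.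

From the compounds shown here alone, whether an amine, a carboxylic acid or a longer hydroxyalkyl chain on this sulfur would match compound 1 remains open.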